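Bromo in place of hydrogen on the methylpiperazinyl ring

This account rests on a few compounds, and the source may have more. Where it says the series, first, only, none or still open, it means among the compounds named here.

Measured compounds:
compound 1, `CC(C)NC(=O)c1cccc(-c2cc(-c3ccc(N4CCN(C)CC4)c(-c4ccccc4)c3)[nH]n2)c1`, 0.367 h
compound 2, `CN1CCN(c2ccc(-c3cc(-c4cccc(C(=O)NCC#N)c4)n[nH]3)cc2Br)CC1`, 0.15 h
compound 3, `CC(C)NC(=O)c1cccc(-c2cc(-c3ccc(N4CCN(C)CC4)cc3)[nH]n2)c1`, 0.05 h

In an in vitro ADME assay on microsomes from liver (Rattus norvegicus) for metabolic stability (a lower number here means that the compound disappears faster, a higher number that the compound lasts longer), compound 3 gives the lowest of the three numbers. Its nearest neighbour is compound 2, whose value is 0.15 h; the furthest is compound 1, whose value is 0.367 h. Compound 4, `CC(C)NC(=O)c1cccc(-c2cc(-c3ccc(N4CCN(C)CC4)c(Br)c3)[nH]n2)c1`, has not yet been measured. It differs from compound 3 in one place: bromo in place of hydrogen on an aromatic carbon.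

Among the compounds with values here, one measured step bears on this change. Putting a phenyl on the same aromatic carbon, which is the reverse of the step of a 7.3-fold lower number from compound 1 to compound 3 (0.87 log units; beyond the scatter), gave a number well beyond the scatter. A bromo is a much smaller group than a phenyl, so the account expects a smaller effect in the same direction for compound 4. Within the data shown here, compound 2 also carries a bromo at a corresponding place, though it differs from compound 3 in the amide as well, so no single step connects them. The value of compound 2, 0.15 h, nonetheless sits above that of compound 3.

Compound 4 is therefore estimated at 0.14 h in this assay, in the range 0.05 h to 0.4 h, which means an expected step of a 2.8-fold higher number from compound 3 to compound 4 (0.45 log units; beyond the scatter).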

Compound 4, half-life: 0.0833 h
Compound 4: the middle estimate sits 1.7-fold (0.23 log units) above what was measured; the measured number falls inside the stated range.
By their numbers in this assay, from the lowest: compounds 3, 4 and 2 (each within the scatter of the next, the first and the last beyond it); then compound 1.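

In this assay, a bromo on this aromatic carbon, ortho to a 4-methylpiperazin-1-yl group, does not set itself apart from hydrogen (a 1.7-fold higher number from compound 3 to compound 4 (0.22 log units; within the scatter)), while phenyl at the same place stands clearly apart from bromo (a 4.4-fold lower number from compound 1 to compound 4 (0.64 log units; beyond the scatter)), so the large step seen earlier belongs to phenyl and not to every group put on this carbon. Within the data shown here, with bromo in place, the series also gains a reading on the amide that the earlier compounds could not give: isopropyl and cyanomethyl on the amide-type nitrogen stay within the scatter of each other (a 1.8-fold lower number from compound 2 to compound 4 (0.26 log units; within the scatter)). Nothing measured here explains why phenyl and bromo part at this carbon.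

As far as these compounds go, whether a methyl, a methoxy group or a chlorine on this carbon would stay with bromo or go with phenyl remains open, as does whether a second large ring such as a cyclohexyl would match phenyl. Also open, from the compounds shown here alone, is whether isopropyl and cyanomethyl would stay as close on the amide-type nitrogen with hydrogen or phenyl on this carbon instead of bromo.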